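From a bare hydrazide to an isopropyl benzylidene hydrazone

The source may report more compounds than this note shows. Statements on the series, on what has been measured and on what is new or still open speak of the compounds shown alone.

Compound 3 `NNC(=O)CCN1CCN(c2ccnc3cc(Cl)ccc23)CC1` carries a free amino group on its amide-type nitrogen. In an ADME assay on cells (Splenocyte, Mus musculus, strain BALB/c) for cytotoxicity, read by thymidine incorporation, with a stated time of 24 h (a higher number here means a weaker inhibitor, a lower number a stronger inhibitor), compound 3 gives only a limit, > 100000 nM, and not a number. On the numbers shown it stands at the high, weak end of the set. Compound 1 `O=C(CCN1CCN(c2ccnc3cc(Cl)ccc23)CC1)N/N=C/c1ccc(Cl)cc1` gives 200 nM in this assay, and compound 2 `COc1cc(/C=N/NC(=O)CCN2CCN(c3ccnc4cc(Cl)ccc34)CC2)c(Br)c(OC)c1OC` gives 9600 nM. Within the data shown here, the one measured step that bears on the change under discussion is an at least 500-fold higher number from compound 1 to compound 3 (2.69 log units; beyond the scatter), a large loss when the aryl arm is removed; the size of that step rests on (the limit of > 100000 nM in this assay, at which 1 of the 3 values shown sits). Compound 4 `CC(C)c1ccc(/C=N/NC(=O)CCN2CCN(c3ccnc4cc(Cl)ccc34)CC2)cc1` puts an arm of the same kind back: a group of 11 heavy atoms (10 carbon, 1 nitrogen; one six-membered aromatic ring of carbon only) in place of one nitrogen atom, on an amide-type nitrogen. This change runs opposite to an at least 500-fold higher number from compound 1 to compound 3 (2.69 log units; beyond the scatter), so a large downward step in this assay is expected for compound 4, of about an at least 160-fold lower number from compound 3 to compound 4 (2.22 log units; beyond the scatter), though the ring substituent differs from both measured hydrazones. Compound 4 is therefore estimated at 600 nM, within a range from 120 nM to 6000 nM.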

Compound 4, half-maximal inhibitory concentration: 7900 nM
Estimate against measurement, compound 4: 13-fold (1.12 log units) below; measured number outside the range, above it.
By their numbers in this assay, from the lowest: compound 1; then compounds 4 and 2 (each within the scatter of the next). At a limit, above all of these: compound 3.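

Restoring an aryl arm on the amide-type nitrogen does not depend on the chloro group: with isopropyl on the ring, this assay still shows an at least 12-fold lower number from compound 3 to compound 4 (1.10 log units; beyond the scatter), so the lower number also appears with a second ring substituent. That step can only be read as a minimum, since it rests on a limit for compound 3: the limit of > 100000 nM in this assay, at which 1 of the 4 values shown sits. The ring substituent also carries much weight, as isopropyl in place of chloro on an aromatic carbon gives a 40-fold higher number from compound 1 to compound 4 (1.60 log units; beyond the scatter), so the arm alone does not bring the number down to that of compound 1.

The compounds shown leave open how a fluoro, a methyl or a carboxylic acid would compare with chloro and isopropyl on the ring. They also leave open what an amine or a longer chain on the amide-type nitrogen would give.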